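Adding a Methoxy Group in Two Related Pairs

The source may hold more compounds than are shown below. What is called first, only, known or untested is meant among the compounds shown, and "the series" means these compounds.

Compound 1 `COc1ccc(/C=C/C(=O)/C=C/c2cc3ccccc3nc2Oc2ccccc2)c(OC)c1` and compound 2 `COc1cc(OC)c(OC)cc1/C=C/C(=O)/C=C/c1cc2ccccc2nc1Oc1ccccc1` share one core, while compound 3 `COc1ccc(/C=C/C(=O)/C=C/c2cc3ccccc3nc2Oc2cccc(Cl)c2)cc1OC` and the not yet measured compound 4 `COc1cc(OC)c(OC)cc1/C=C/C(=O)/C=C/c1cc2ccccc2nc1Oc1cccc(Cl)c1` share another; the difference between the two cores is not broken down here. In a functional assay on DU-145 cells (Homo sapiens) for cytotoxicity, read by MTT assay, with a stated time of 48 h (on this read-out higher numbers stand for weaker inhibition and lower numbers for stronger inhibition), compound 1 gives only a limit of the assay, > 10000 nM. Compound 2 gives 9220 nM in this assay. The change between these two is methoxy in place of hydrogen on an aromatic carbon, and the step it made is an at least 1.0-fold lower number from compound 1 to compound 2 (0.03 log units; that floor lies within the scatter). Compound 3 gives only a limit in this assay, > 10000 nM. The change from compound 3 to compound 4 is methoxy in place of hydrogen on an aromatic carbon. It is the same kind of change, but the surroundings differ: in the first pair the entering group sits ortho to a methoxy group and meta to a large group, whereas here it sits ortho to a large group and meta to a methoxy group. Two of the three values sit at the same limit, (the limit of > 10000 nM in this assay, at which 2 of the 3 values shown sit). The step is expected to be a step that the limit leaves unreadable from compound 3 to compound 4, a small one, resting on the step of an at least 1.0-fold lower number from compound 1 to compound 2 (0.03 log units; that floor lies within the scatter) seen in the first pair. Compound 4 is therefore estimated at 12000 nM, within a range from 5000 nM to 30000 nM, with a real chance that only a limit is reported again.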

Compound 4, half-maximal inhibitory concentration: > 10000 nM
Compound 4: only a limit was reported; the forecaster's own chance of this, stated with the estimate: 55%; the middle value does not contradict the limit.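

In this assay, the step from compound 3 to compound 4 cannot be read, since both of its ends are limits of the assay and not numbers: the limit of > 10000 nM in this assay, at which 3 of the 4 values shown sit.

The methoxy change therefore cannot be shown either to carry over from the core of compound 1 to the core of compound 3 or to fail to do so, and replacing 3,4-dimethoxyphenyl with 2,4,5-trimethoxyphenyl has no readable size in the second core. Among these compounds, the one other comparison, chloro in place of hydrogen on an aromatic carbon, gives an at least 1.0-fold higher number from compound 2 to compound 4 (0.03 log units; that floor lies within the scatter), and because that figure is only a floor, it does not fix how large the true step is.

From the compounds shown here alone, only compound 2 has a measured number here, so it remains open whether this methoxy change would have a readable size in a pair in which both compounds give numbers. Going by these compounds, it also remains open what an amine or a carboxylic acid in place of the chloro group would give.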